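A few compounds are considered here, and "the series" means these few. Any claim that something is new, unique, unknown or untested is made for them only; others in the source may bear on it.

Three compounds have been measured in a physicochemical assay for lipophilicity, in phosphate buffer, measured as octanol-water partition, at pH 11.5; a higher number here means a more lipophilic compound, a lower number a more polar compound:

- compound 1 `CCCCSc1ccc(NC(=N)NC(=N)NCCCCCCNC(=N)NC(=N)Nc2ccc(SCCCC)cc2)cc1`: 7.58
- compound 2 `CCCCCCCCCCCCNC(=N)NC(=N)Nc1ccc(Cl)cc1`: 7.13
- compound 3 `CCCCCSc1ccc(NC(=N)NC(=N)NCCCCCCNC(=N)NC(=N)Nc2ccc(SCCCCC)cc2)cc1`: 8.58

Compound 2 stands lowest of the three at 7.13. Compound 1 lies nearest at 7.58 and compound 3 furthest at 8.58, both gaps being beyond the scatter.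

Compound 4 `CCCCNC(=N)NC(=N)Nc1ccc(Cl)cc1` has not yet been measured. It departs from compound 2 by hydrogen in place of octyl on a saturated chain carbon, four bonds along the chain from an amine nitrogen. Among the compounds with values here, no measured pair differing in one place offers a guide, so the expectation rests on the structural change alone. In this assay the expected step is a number 3.93 log units lower from compound 2 to compound 4 (beyond the scatter), a large fall well beyond the scatter. The estimated value for compound 4 is 3.2, with an expected range from 2.4 to 4.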

Compound 4, partition coefficient: 3.13
Compound 4: the middle estimate sits 0.07 log units above what was measured; the measured number falls inside the stated range.
By their numbers in this assay, from the lowest: compound 4; then compound 2; then compound 1; then compound 3.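

Hydrogen in place of octyl on a saturated chain carbon, four bonds along the chain from an amine nitrogen, gives in this assay a number 4.00 log units lower from compound 2 to compound 4 (beyond the scatter) and is the only comparison here of compounds that differ in one place. Within the data shown here, it shows that the read-out depends strongly on the chain at this position, which the earlier compounds could not show. Nothing available accounts for the size of this fall. On these data alone, whether an intermediate chain, such as hexyl, would give a proportionate number remains open, as does the effect of a terminal hydroxyl group on the chain.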